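Phenethyl in Place of Phenyl: Two Measured Compounds, One Awaited

This account rests on a few compounds, and the source may have more. Where it says the series, first, only, none or still open, it means among the compounds named here.

compound 1, `CCCc1n[nH]c2c(=O)n(NC(=O)c3ccncc3)c(-c3cccc(OC)c3)nc12`: 9.13%
compound 2, `O=C(Nn1c(-c2ccccc2)nc2c(-c3ccc(Cl)cc3)n[nH]c2c1=O)c1ccccc1`: 90.2%

In a functional assay on DU-145 cells (Homo sapiens) for cytotoxicity, read by sulforhodamine B assay, with a stated time of 2 days, tested at 100 uM (on this read-out higher numbers stand for more inhibition at the one concentration tested (going by the name of the read-out) and lower numbers for less inhibition), compound 2 gives 90.2%, the highest of the two numbers measured. Compound 1 gives 9.13%, a gap beyond the usual scatter. The two compounds differ in several places at once, so the data hold no single change between measured compounds to lean on.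

Compound 3, `O=C(Nn1c(CCc2ccccc2)nc2c(-c3ccc(Cl)cc3)n[nH]c2c1=O)c1ccccc1`, keeps the core of compound 2 and changes it in one place: phenethyl in place of phenyl on an aromatic carbon. For the measured compounds named here, no measured pair shows what this change does, so the expectation rests only on compound 2.

Because compound 2 reaches 90.2% in this assay, compound 3 is expected to give a number that stays high, with a step estimated as a modest decrease, a number 18.2 percentage points lower from compound 2 to compound 3 (beyond the scatter), possibly within the scatter. The estimate for compound 3 is 72%, with a range from 35% to 95%.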

Compound 3, a percentage reported as inhibition, at one concentration (the size of the read-out at that concentration, not a potency): 85.6%
Estimate against measurement, compound 3: 13.6 percentage points below, and the stated range covers the measured number.
By their numbers in this assay, from the lowest: compound 1; then compounds 3 and 2 (each within the scatter of the next).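

In this assay, phenethyl in place of phenyl on the aromatic carbon between two ring nitrogen atoms gives a number 4.6 percentage points lower from compound 2 to compound 3 (within the scatter), so on the core of compound 2 this position accepts either group with no change that can be told from the scatter. For the compounds shown here, this is the first single change that can be read at this position, since compound 1 and compound 2 differ in several places at once and could not show it. Nothing shown here gives a reason for this result.

As far as these compounds go, it stays open whether the position also accepts a group of another kind, such as an amine, a carboxylic acid or a chain longer than phenethyl. From the compounds shown here alone, it also stays open whether the same change would give a similar step on the core of compound 1, and the single tested concentration says nothing about potency.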